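A few compounds are considered here, and "the series" means these few. Any claim that something is new, unique, unknown or untested is made for them only; others in the source may bear on it.

Measured compounds in a functional assay on DU-145 cells (Homo sapiens) for antiproliferative activity, read by sulforhodamine B assay, with a stated time of 48 h; a lower number here means a stronger inhibitor of growth, a higher number a weaker inhibitor of growth:

compound 1, `Nc1nn(C(=O)Nc2ccc(Cc3ccccc3)cc2)c2ccccc12`, 1020 nM
compound 2, `Nc1nn(C(=O)Nc2ccc(Cc3ccccc3)cc2)c2ccc(Cl)cc12`, 10400 nM

Compound 2 stands highest of the two numbers in this assay; its nearest neighbour is compound 1, and the step of a 10-fold higher number from compound 1 to compound 2 (1.01 log units; beyond the scatter) lies beyond the scatter, so compound 2 is the weaker inhibitor of the pair. The only structural difference between them is the chloro on the aromatic carbon of the fused core of compound 2.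

Compound 3, `Nc1ccc2c(c1)c(N)nn2C(=O)Nc1ccc(Cc2ccccc2)cc1`, is to be measured next. It differs from compound 2 by amino in place of chloro on an aromatic carbon, on the aromatic carbon of the six-membered carbon-only ring of the fused system, meta to a fused ring and para to a fused ring. Going by the values given here, the one measured step that bears on this position is a 10-fold higher number from compound 1 to compound 2 (1.01 log units; beyond the scatter), which shows that a chloro there raised the number markedly. Among the compounds with values here, no measured step shows what an amino at this position does, so the direction of the change from compound 2 to compound 3 cannot be read from the data. The step expected is a 3.0-fold lower number from compound 2 to compound 3 (0.47 log units; beyond the scatter), with wide uncertainty. Compound 3 is therefore estimated at 3500 nM in this assay, with a range from 800 nM to 15000 nM.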

Compound 3, concentration for 50% growth inhibition: 10900 nM
The estimate for compound 3 lay 3.1-fold (0.49 log units) below the measured number, within the range that was stated.
By their numbers in this assay, from the lowest: compound 1; then compounds 2 and 3 (each within the scatter of the next).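

In this assay, amino in place of chloro on this aromatic carbon gives a 1.0-fold higher number from compound 2 to compound 3 (0.02 log units; within the scatter), so the two groups cannot be told apart here, although amino carries a hydrogen-bond donor and a hydrogen-bond acceptor and chloro carries neither. Measured against hydrogen at the same carbon, amino gives an 11-fold higher number from compound 1 to compound 3 (1.03 log units; beyond the scatter), a large step that matches a 10-fold higher number from compound 1 to compound 2 (1.01 log units; beyond the scatter), so the higher number seen with chloro is now also seen with a second, different group, and among these three compounds only hydrogen gives the lowest number. Nothing given here explains why chloro and amino give such similar numbers at this position.

The compounds shown leave open whether any other group on this carbon, such as fluoro, methyl or hydroxyl, would keep the number near that of compound 1, or whether every replacement of hydrogen here gives a large step. They also leave open whether amino or chloro would have the same effect on another aromatic carbon of the six-membered ring, or with a group other than benzyl on the far phenyl ring.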